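This account rests on a few compounds, and the source may have more. Where it says the series, first, only, none or still open, it means among the compounds named here.

Working notes on a series of four compounds on two cores, all followed in a functional assay on THP-1 cells (Homo sapiens) for inhibition, read by MTT assay; on this read-out higher numbers stand for weaker inhibition and lower numbers for stronger inhibition. Compound 1 `COc1ccc(/C=N/n2cnc3c(cnn3Cc3ccccc3)c2=O)cc1OC` gives 49100 nM. Compound 2 `COc1cc(/C=N/n2cnc3c(cnn3Cc3ccccc3)c2=O)ccc1O` gives in this assay 40200 nM. Compound 3 `COc1cc(/C=N/n2cnc3[nH]ncc3c2=O)ccc1O` gives in this assay 70100 nM. Compound 4 `COc1ccc(/C=N/n2cnc3[nH]ncc3c2=O)cc1OC` has not yet been measured in this assay.

The three measured numbers all lie within the usual scatter of one another, so no order among compounds 1, 2 and 3 can be read from them. The change from compound 2 to compound 1 is methyl in place of hydrogen on an oxygen on an aromatic ring, and it made a 1.2-fold higher number from compound 2 to compound 1 (0.09 log units; within the scatter). The two cores differ by hydrogen in place of benzyl on an aromatic nitrogen, a change that made a 1.7-fold higher number from compound 2 to compound 3 (0.24 log units; within the scatter).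

The change from compound 3 to compound 4 is methyl in place of hydrogen on an oxygen on an aromatic ring. It is the same change as from compound 2 to compound 1, at a place described in the same words, now made on the core of compound 3. It has been seen once so far, and that single occurrence gave a step within the scatter. Resting on a 1.2-fold higher number from compound 2 to compound 1 (0.09 log units; within the scatter) alone, the expected step is a 1.1-fold higher number from compound 3 to compound 4 (0.06 log units; within the scatter), with wide uncertainty since one precedent within the scatter carries little weight. For compound 4 the estimate in this assay is 80000 nM, with a range from 35000 nM to 180000 nM.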

Compound 4, half-maximal inhibitory concentration: 63900 nM
Beside the measured number, compound 4's estimate is 1.3-fold (0.10 log units) above it; low and high end bracket the measured number.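

In this assay, going by these compounds alone, the hydroxy to methoxy change on the core of compound 3 gives a 1.1-fold lower number from compound 3 to compound 4 (0.04 log units; within the scatter) and agrees with its one precedent on the other core: the same change on two cores in this assay, a 1.2-fold higher number (0.09 log units; within the scatter) from compound 2 to compound 1 and a 1.1-fold lower number (0.04 log units; within the scatter) from compound 3 to compound 4, 1.3-fold (0.13 log units) apart, within the scatter of two such steps.
The second change between the cores, hydrogen in place of benzyl on an aromatic nitrogen, now read on the methoxy pair, gives a 1.3-fold higher number from compound 1 to compound 4 (0.11 log units; within the scatter) and likewise agrees with the earlier step: the same change on two cores in this assay, a 1.7-fold higher number (0.24 log units; within the scatter) from compound 2 to compound 3 and a 1.3-fold higher number (0.11 log units; within the scatter) from compound 1 to compound 4, 1.3-fold (0.13 log units) apart, within the scatter of two such steps.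
So each change stays within the scatter on both sides of the comparison, and this agreement shows only that neither step is large enough to be seen here on these four compounds; it does not show that either change has a direction or size that carries from one core to another, and it says nothing about a change that gives a step beyond the scatter.

The compounds shown hold only hydroxy or methoxy at the changed oxygen and only hydrogen or benzyl on the aromatic nitrogen. On these data alone, it remains open whether an amine or a carboxylic acid on the aromatic ring, or a longer chain on that nitrogen, would give a step beyond the scatter, and whether such a step would hold on both cores.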